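Lengthening the Chain of a Weakly Active Amine

The source may report more compounds than this note shows. Statements on the series, on what has been measured and on what is new or still open speak of the compounds shown alone.

In a functional assay on MCF7 cells (Homo sapiens) for antiproliferative activity, read by MTT assay, with a stated time of 72 h (on this read-out higher numbers stand for weaker inhibition and lower numbers for stronger inhibition), compound 1 `CCCCCCCNC[C@@H]1OC[C@H](N)[C@@H]1O` reaches only the limit > 128000 nM and so gives no actual number. Among the compounds with values here, compound 2 `CCCCCCCCCNC[C@@H]1OC[C@H](N)[C@H]1O` reads 60300 nM in this assay and this is the only true number so far, which makes it the single firm reference point for what follows.

Compound 3 `CCCCCCCCCCCNC[C@@H]1OC[C@H](N)[C@H]1O` keeps the shared core of compound 2 and carries a longer chain. The change is ethyl in place of hydrogen on a saturated chain carbon, nine bonds along the chain from an amine nitrogen and nothing else differs.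

Within the data shown here, no measured step is available to guide the size of this one, so it must be judged. Compound 2 at 60300 nM leaves ample room for a lower number, and a moderate step toward stronger inhibition, somewhat beyond the usual scatter, is expected. The estimated change is a 3.0-fold lower number from compound 2 to compound 3 (0.48 log units; beyond the scatter) in this assay as a best guess. For compound 3 the expected value is 20000 nM with an estimated range from 7000 nM to 55000 nM in this assay once it is measured.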

Compound 3, half-maximal inhibitory concentration: 13100 nM
Compound 3: middle estimate off by 1.5-fold (0.18 log units), on the high side; the measured number falls inside the stated range.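

Within the data shown here, this is the first step that can be read as a number, and it shows that the far part of the chain is not a silent position. In this assay, ethyl in place of hydrogen on a saturated chain carbon, nine bonds along the chain from an amine nitrogen, gives a 4.6-fold lower number from compound 2 to compound 3 (0.66 log units; beyond the scatter), so adding to the chain here moves the read-out toward stronger inhibition by a modest but real amount. Compound 1 gives a limit and not a number, so any step to it cannot be read: the limit of > 128000 nM in this assay, at which 1 of the 3 values shown sits.

As far as these compounds go, a single lengthening is only one point, so it remains open whether a longer chain would lower the number further, make no difference or raise it again. From the compounds shown here alone, it also remains open whether carbon alone at the chain end matters, which a chain ending in an amine, a carboxylic acid or a phenyl ring could help to settle.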